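From a Methylsulfonyl to a Hydroxypropyl Side Chain

The source may report more compounds than this note shows. Statements on the series, on what has been measured and on what is new or still open speak of the compounds shown alone.

Of the compounds shown here, three built on one shared core have been measured in a functional assay for inhibition, with Homo sapiens as the target; a higher number here means a weaker inhibitor, a lower number a stronger inhibitor. Compound 1 `O=C(O)COc1cccc(/C=C/c2nc(-c3ccccc3)c(-c3ccccc3)o2)c1` gives 13000 nM in this assay. Compound 2 `CCOC(=O)/C(=C\c1cccc(OCC(=O)OC)c1)c1nc(-c2ccccc2)c(-c2ccccc2)o1` gives 2000 nM in this assay. Compound 3 `CS(=O)(=O)C(Cc1cccc(OCC(=O)O)c1)c1nc(-c2ccccc2)c(-c2ccccc2)o1` gives 7960 nM in this assay. Among these three numbers compound 3 stands second highest; its nearest neighbour is compound 1, whose number lies within the scatter of that of compound 3, so no order can be claimed between the two, whereas the number of compound 2 lies beyond the scatter on the lower side.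

Among the compounds with values here, no two of the measured compounds differ from each other in a single place, so no step between measured compounds can be read. Compound 4 `O=C(O)COc1cccc(CC(CCCO)c2nc(-c3ccccc3)c(-c3ccccc3)o2)c1` has not yet been measured. It differs from compound 3 in this way: 3-hydroxypropyl in place of methylsulfonyl on a saturated chain carbon bound to an aromatic carbon and a saturated chain carbon

Within the data shown here, the rest of the molecule is left unchanged, and the measured compounds offer no step of this kind to lean on. Compound 3, at 7960 nM, is the only anchor. The step of a 1.3-fold lower number from compound 3 to compound 4 (0.12 log units; within the scatter) is expected to be small, with no clear direction beyond the scatter. In this assay compound 4 is estimated at 6000 nM, with a range from 1500 nM to 25000 nM.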

Compound 4, half-maximal inhibitory concentration: 1700 nM
The estimate for compound 4 lay 3.5-fold (0.55 log units) above the measured number; low and high end bracket the measured number.
By their numbers in this assay, from the lowest: compounds 4 and 2 (each within the scatter of the next); then compounds 3 and 1 (each within the scatter of the next).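

In this assay, within the data shown here, the saturated chain carbon bound to an aromatic carbon and a saturated chain carbon proves sensitive to what it carries: 3-hydroxypropyl in place of methylsulfonyl gives a 4.7-fold lower number from compound 3 to compound 4 (0.67 log units; beyond the scatter), a modest step and the only single-place comparison in this set. The swap keeps the count at 4 heavy atoms, while the sulfur and both double bonds outside aromatic rings leave and a hydrogen-bond donor enters, so methylsulfonyl is shown not to be needed at this place for the number of compound 3 to be matched or bettered. Nothing measured here bears on why the number moves.

Among these compounds, the single step cannot separate the contribution of the hydroxyl from that of the three-carbon chain, and a plain propyl group or a methoxypropyl group at this place would be needed to tell them apart. Going by these compounds, it also remains open how the number would respond to an amine or a carboxylic acid in place of the hydroxyl, or to a longer chain carrying the same hydroxyl.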